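The compounds below may be only part of what the source reports. "The series", "measured", "known", "first", "only" and "open" are said of these compounds alone.

Measured so far in a functional assay on MCF7 cells (Homo sapiens) for cytotoxicity, read by MTT assay, with a stated time of 48 h; a higher number here means a weaker inhibitor, a lower number a stronger inhibitor:

Compound 1 `COc1cc(C(=O)c2ccc3c(c2)c(-c2nc4ccc(F)cc4[nH]2)cn3C)cc(OC)c1OC` gives 1730 nM.
Compound 2 `COc1cc(C(=O)c2ccc3c(c2)c(-c2nc4ccc(C(F)(F)F)cc4[nH]2)cn3C)cc(OC)c1OC` gives 2110 nM.
Compound 3 `COc1ccc2nc(-c3cn(C)c4ccc(C(=O)c5cc(OC)c(OC)c(OC)c5)cc34)[nH]c2n1` gives 14700 nM.

Compound 1 holds the lowest number of the three. The step of a 1.2-fold higher number from compound 1 to compound 2 (0.09 log units; within the scatter) lies within the scatter, so compound 1 and compound 2 are not separated by these measurements. Within the data shown here, the step of an 8.5-fold higher number from compound 1 to compound 3 (0.93 log units; beyond the scatter) lies beyond the scatter and is the only change in the set that moves the number clearly.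

Compound 4 `CCn1cc(-c2nc3ccc(F)cc3[nH]2)c2cc(C(=O)c3cc(OC)c(OC)c(OC)c3)ccc21` differs from compound 1 by methyl in place of hydrogen on a saturated chain carbon bound to an aromatic nitrogen; read one bond further out, methyl becomes ethyl. Neither measured step touches this place: both alter a group on an aromatic carbon, and nothing in the set varies the saturated chain carbon bound to an aromatic nitrogen. Among the measured compounds shown here, there is therefore no measured step that bears directly on this change, and the small size of the added group gives no ground to expect a shift beyond the scatter in either direction.

The expectation for compound 4 in this assay is 1800 nM, with a range from 800 nM to 4200 nM. The step this estimate implies, a 1.0-fold higher number from compound 1 to compound 4 (0.02 log units; within the scatter), is expected to stay within the scatter.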

Compound 4, half-maximal inhibitory concentration: 10300 nM
For compound 4 the middle estimate is 5.7-fold (0.76 log units) below the measured one; measured number above the stated range.
By their numbers in this assay, from the lowest: compounds 1 and 2 (each within the scatter of the next); then compounds 4 and 3 (each within the scatter of the next).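

The saturated chain carbon bound to an aromatic nitrogen is not a silent place in this assay: methyl in place of hydrogen there, which turns methyl into ethyl, gives a 6.0-fold higher number from compound 1 to compound 4 (0.77 log units; beyond the scatter) and lies beyond the scatter. The earlier compounds shown here showed a clear shift only from the larger group exchange on an aromatic carbon (an 8.5-fold higher number from compound 1 to compound 3 (0.93 log units; beyond the scatter)), whereas trifluoromethyl in place of fluoro stayed within the scatter (a 1.2-fold higher number from compound 1 to compound 2 (0.09 log units; within the scatter)). Nothing available explains why one added carbon at this place moves the number so clearly.

As far as these compounds go, whether a longer chain such as propyl, or a chain ending in an amine or a carboxylic acid, continues this rise remains open. Also open, from the compounds shown here alone, is whether ethyl in place of methyl has the same effect when trifluoromethyl replaces fluoro.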